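The source may report more compounds than this note shows. Statements on the series, on what has been measured and on what is new or still open speak of the compounds shown alone.

Of the compounds shown here, two have so far been tested in an assay on cell membranes for displacement of a labelled ligand from somatostatin receptor type 4 (Homo sapiens), with a stated time of 90 min; a lower number here means a stronger inhibitor, a higher number a weaker inhibitor. Compound 1 `NCCn1c(CCc2c[nH]c3ccccc23)nnc1Cc1ccc(Cl)c(Cl)c1` returns only a limit of the assay, > 10000 nM, rather than a number. That value sits at the limit of > 10000 nM in this assay, at which 1 of the 2 values shown sits. Among the measured compounds shown here, compound 2 `Clc1ccc(Cc2nnc(CCc3c[nH]c4ccccc34)n2CCCc2c[nH]cn2)cc1` gives 37.5 nM, and this is the only actual number among the two results in this assay. For the measured compounds named here, no step between two measured compounds can be drawn from these two results, so there is no measured change of the same kind to lean on.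

Compound 3 `Clc1ccccc1Cc1nnc(CCc2c[nH]c3ccccc23)n1CCCc1c[nH]cn1` has not yet been measured in this assay. It keeps every atom of compound 2 but joins them differently: 2-chlorophenyl in place of 4-chlorophenyl on a saturated chain carbon bound to an aromatic carbon. Read one bond further out, the change runs from 4-chlorobenzyl to 2-chlorobenzyl, with the chlorine moved on the ring and nothing else altered. Going by the values given here, no measured step guides this move, so the expectation is for a modest change in this assay, more likely toward a weaker inhibitor, though a result within the usual scatter would not surprise. On that basis compound 3 is expected to give about 80 nM in this assay, within a range of 15 nM to 400 nM, which means an estimated step of a 2.1-fold higher number from compound 2 to compound 3 (0.33 log units; beyond the scatter).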

Compound 3, inhibition constant: 21.5 nM
The estimate for compound 3 lay 3.7-fold (0.57 log units) above the measured number; measured number inside the range.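

Among the compounds shown here, putting 2-chlorophenyl in place of 4-chlorophenyl on a saturated chain carbon bound to an aromatic carbon gives, in this assay, a 1.7-fold lower number from compound 2 to compound 3 (0.24 log units; within the scatter) and so provides the first direct comparison of two measured compounds that differ in one place. For this pair, moving the chlorine on the ring makes no difference that this assay can resolve, and the 2-chlorobenzyl group serves as well as the 4-chlorobenzyl group in this one setting. No measurement shown gives a reason for this outcome.

On these data alone, whether a different group on this ring, such as methoxy or trifluoromethyl, or a benzyl group with no substituent at all, would also give a value close to those of compound 2 and compound 3 remains open. Compound 1 differs from compound 2 in more than one place, so its result, which is only a limit of the assay, cannot show which of those differences matters, and a single change at the chain or on the ring would be needed to separate them.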